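A trifluoromethyl group enters the aromatic ring of compound 1

A few compounds are considered here, and "the series" means these few. Any claim that something is new, unique, unknown or untested is made for them only; others in the source may bear on it.

Measured compounds:
Compound 1 `O=C1C=CC(OCC(F)(F)F)N1c1ccccc1`: in a functional assay on HeLa cells (Homo sapiens) for inhibition (on this read-out lower numbers stand for stronger inhibition and higher numbers for weaker inhibition), compound 1 gives > 100000 nM, which is a limit of the assay and not a number.
Compound 2 `O=C1C=CC(OCC(F)(F)F)N1c1ccc(F)c(Cl)c1`: in this assay compound 2 gives 3110 nM.
Compound 3 `O=C1C=CC(OCC(F)(F)F)N1c1ccccc1F`: in this assay compound 3 gives 19300 nM.

Compound 1 stands at the edge of what this assay reports; of the three values shown, only compound 1 sits there (the limit of > 100000 nM in this assay, at which 1 of the 3 values shown sits). Compound 2 and compound 3 both fall inside the measurable range. Within the data shown here, the single measured step that changes one place on compound 1 is an at least 5.1-fold lower number from compound 1 to compound 3 (0.71 log units; beyond the scatter). Compound 4 `O=C1C=CC(OCC(F)(F)F)N1c1ccc(C(F)(F)F)cc1` differs from compound 1 as follows: trifluoromethyl in place of hydrogen on an aromatic carbon. The step to compound 3 bears on this change, as the one case in which a group enters the aromatic ring of compound 1, and it moved the number beyond the scatter. A step in the same direction is therefore expected for compound 4, of a size comparable to that step. Compound 4 is estimated at 15000 nM, with a range from 4000 nM to 60000 nM. This estimate means an expected step of an at least 6.6-fold lower number from compound 1 to compound 4 (0.82 log units; beyond the scatter).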

Compound 4, half-maximal inhibitory concentration: 36200 nM
Estimate against measurement, compound 4: 2.4-fold (0.38 log units) below; the measured number falls inside the stated range.
By their numbers in this assay, from the lowest: compound 2; then compounds 3 and 4 (each within the scatter of the next). At a limit, above all of these: compound 1.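

With this result, a second group on the aromatic ring, and a larger one than the fluoro of compound 3, brings the number inside the measurable range. In this assay, among these compounds, trifluoromethyl on an aromatic carbon para to a large group gives an at least 2.7-fold lower number from compound 1 to compound 4 (0.44 log units; beyond the scatter), which is the first reading for this place on the ring. The value of compound 1 is a limit and not a number, so only the smallest possible size of this step is known: the limit of > 100000 nM in this assay, at which 1 of the 4 values shown sits.

The compounds shown leave open whether a small group such as fluoro, chloro or methyl at this same place would give a similar step. They also leave open how an amine, a carboxylic acid or a methoxy group there would read in this assay.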